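The source may hold more compounds than are shown below. What is called first, only, known or untested is meant among the compounds shown, and "the series" means these compounds.

Measured compounds in a functional assay with platelet-activating factor receptor (Cavia porcellus) as the target; on this read-out higher numbers stand for an effect only at larger amounts of compound and lower numbers for an effect already at smaller amounts:
- compound 1, `CCCC/C(=C\C=C\C(=O)N[C@H](C)CCCc1cccnc1)c1ccc(OC)cc1`, gives 0.68 mg/kg
- compound 2, `COc1ccc(C(=C/C=C/C(=O)NCCCCc2cccnc2)c2ccc(OC)c(OC)c2)cc1OC`, gives 0.54 mg/kg
- compound 3, `Cc1ccc(C(=C/C=C/C(=O)N[C@H](C)CCCc2cccnc2)c2ccc(C)cc2)cc1`, gives 0.3 mg/kg

Among these three, compound 1 has the highest number. Compound 2 stands within the scatter of compound 1, so the two cannot be told apart on this assay. Compound 3 lies beyond the scatter of compound 1, with the lower number of the two.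

Compound 4, `COc1ccc(/C(=C/C=C/C(=O)N[C@H](C)CCCc2cccnc2)c2ccccc2)cc1`, has not yet been measured. It differs from compound 1 in one place: phenyl in place of butyl on a double-bonded chain carbon bound to an aromatic carbon and a double-bonded chain carbon. With this change compound 4 carries two aromatic rings on the double-bonded chain carbon, as compounds 2 and 3 do, while compound 1 carries one ring and a butyl chain there. Among the measured compounds shown here, no measured pair shows this exact step, so its size is unknown. Because compound 2 gives 0.54 mg/kg and compound 3 gives 0.3 mg/kg, both carrying two rings on that carbon, compound 4 is expected to give a somewhat lower number than compound 1, though the step may stay within the scatter. Compound 4 is estimated at 0.42 mg/kg, within 0.2 mg/kg to 0.9 mg/kg, a step of a 1.6-fold lower number from compound 1 to compound 4 (0.21 log units; within the scatter) as expected.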

Compound 4, dose for 50% inhibition: 0.16 mg/kg
Estimate against measurement, compound 4: 2.6-fold (0.42 log units) above; the whole stated range lies above it.
By their numbers in this assay, from the lowest: compounds 4, 3, 2 and 1 (each within the scatter of the next, the first and the last beyond it).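

In this assay, phenyl in place of butyl on a double-bonded chain carbon bound to an aromatic carbon and a double-bonded chain carbon gives a 4.3-fold lower number from compound 1 to compound 4 (0.63 log units; beyond the scatter). Among the compounds shown here, this is the first step that can be read at this position, as no earlier pair differed in one place, and it shows that the number responds to the group carried there, with the ring giving the lower number in this pair. Nothing at hand gives a cause for this step.

A single pair cannot tell whether the aromatic ring itself counts or only the larger group, and neither a cyclohexyl group nor a longer chain on this carbon stands among the compounds shown. From the compounds shown here alone, whether the step keeps its size without the methyl on the amide side chain also stays open.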